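Same Aryl Swap Expected To Leave Inhibition Unchanged

The source may hold more compounds than are shown below. What is called first, only, known or untested is meant among the compounds shown, and "the series" means these compounds.

Three carbamates built on a shared core have been tested in a functional assay on PANC-1 cells (Homo sapiens) for inhibition, read by MTT assay, with a stated time of 24 h, tested at 10 uM; a lower number here means less inhibition, a higher number more inhibition at the concentration tested (going by the name of the read-out). Compound 1 `COc1ccccc1NC(=O)Oc1cc(=O)n(CCCO)c2c1CC(CC=C(C)C)C(C)(C)C2` gives 0%. Compound 2 `CC(C)=CCC1Cc2c(OC(=O)Nc3ccc(F)cc3)cc(=O)n(CCCO)c2CC1(C)C` gives 0%; it differs from compound 1 by 4-fluorophenyl in place of 2-methoxyphenyl on an amide-type nitrogen, and that step is no change at the digits printed from compound 1 to compound 2 (within the scatter). Compound 3 `COc1ccccc1NC(=O)Oc1cc(=O)n(CCCO)c2c1CC(C/C=C(\C)CCC=C(C)C)C(C)(C)C2` gives 0%; its core differs from that of compound 1 by 3-methylbut-2-en-1-yl in place of hydrogen on a saturated chain carbon bound to a double-bonded chain carbon, and that step is no change at the digits printed from compound 1 to compound 3 (within the scatter). Compound 4 `CC(C)=CCC/C(C)=C/CC1Cc2c(OC(=O)Nc3ccc(F)cc3)cc(=O)n(CCCO)c2CC1(C)C` has not yet been measured. It differs from compound 3 by 4-fluorophenyl in place of 2-methoxyphenyl on an amide-type nitrogen, the same change as from compound 1 to compound 2, now made on the core of compound 3. Because that change once gave no change at the digits printed from compound 1 to compound 2 (within the scatter) and the core change gave no change at the digits printed from compound 1 to compound 3 (within the scatter), the expected step is no change at the digits printed from compound 3 to compound 4 (within the scatter). Compound 4 is therefore estimated to give 0% in this assay.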

Compound 4, a percentage reported as inhibition, at one concentration (the size of the read-out at that concentration, not a potency): 6.2%
Compound 4: middle estimate off by 6.2 percentage points, on the low side; the measured number falls inside the stated range.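

In this assay, 4-fluorophenyl in place of 2-methoxyphenyl on the amide-type nitrogen gives a number 6.2 percentage points higher from compound 3 to compound 4 (within the scatter), and this swap behaves alike on both cores: the same change on two cores in this assay, no change at the digits printed (within the scatter) from compound 1 to compound 2 and a number 6.2 percentage points higher (within the scatter) from compound 3 to compound 4, 6.2 percentage points apart, within the scatter of two such steps

Adding the 3-methylbut-2-en-1-yl group gives a number 6.2 percentage points higher from compound 2 to compound 4 (within the scatter), and this change also behaves alike on both cores: the same change on two cores in this assay, no change at the digits printed (within the scatter) from compound 1 to compound 3 and a number 6.2 percentage points higher (within the scatter) from compound 2 to compound 4, 6.2 percentage points apart, within the scatter of two such steps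

This does not show that either change has a real effect here, nor that a change with a larger effect would carry from one core to another in the same way.

The compounds shown leave open whether a group other than these two aryl rings on the amide-type nitrogen, such as one bearing an amine or a carboxylic acid, would give a step beyond the scatter in this assay.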